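This account rests on a few compounds, and the source may have more. Where it says the series, first, only, none or still open, it means among the compounds named here.

Measured so far in a functional assay on BCG823 cells (Homo sapiens) for inhibition, read by MTT assay, with a stated time of 72 h; a higher number here means a weaker inhibitor, a lower number a stronger inhibitor:
- compound 1 `CN(C(=O)NC(=O)c1ccc([N+](=O)[O-])cc1)c1nc(C(F)(F)F)c(C(=O)N/N=C/c2ccc([N+](=O)[O-])cc2)s1`: 7.45 ug/mL
- compound 2 `CNc1nc(C)c(C(=O)N/N=C/c2ccc(C(F)(F)F)cc2)s1`: > 100 ug/mL

Among the compounds with values here, compound 1 is the only compound of the pair with a numerical reading in this assay, so it stands alone as the reference point of the series. For compound 2 the reading is a limit and not a number, given by the limit of > 100 ug/mL in this assay, at which 1 of the 2 values shown sits. Within the data shown here, no step between two measured compounds is available, since compound 1 and compound 2 differ in several places at once, and their two values show only that one gives a number while the other stops at the limit.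

The unmeasured compound 3 `CN(C(=O)NC(=O)c1ccc(F)c(F)c1)c1nc(C(F)(F)F)c(C(=O)N/N=C/c2ccc([N+](=O)[O-])cc2)s1` keeps the shared core of compound 1 and differs in one place: 3,4-difluorophenyl in place of 4-nitrophenyl on a carbonyl carbon.

Among the measured compounds shown here, with no measured step to lean on, the expectation for compound 3 is a step of the order of the scatter, leaning toward weaker, as stated in a 1.6-fold higher number from compound 1 to compound 3 (0.21 log units; within the scatter). The estimate for compound 3 in this assay is 12 ug/mL, with a range from 4 ug/mL to 40 ug/mL.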

Compound 3, half-maximal inhibitory concentration: 2.99 ug/mL
Estimate against measurement, compound 3: 4.0-fold (0.60 log units) above; the measured number lies below the stated range.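

The carbonyl carbon whose other neighbour is an amide-type nitrogen now has its first readable step: in this assay, 3,4-difluorophenyl in place of 4-nitrophenyl gives a 2.5-fold lower number from compound 1 to compound 3 (0.40 log units; beyond the scatter). The step is modest, but it shows that the shared core does not need 4-nitrophenyl at this place to give a numerical reading, and that a nitro-free aromatic ring of carbon only can be carried here with a lower number in this assay. Nothing measured in the series bears on the cause of this step.

With a single replacement at this place, the loss of the nitro group cannot be separated from the entry of the two fluorines, and plain phenyl, 4-fluorophenyl, 4-chlorophenyl, 4-methoxyphenyl or a pyridine ring on the same carbonyl would begin to tell these apart. Steps involving compound 2 cannot be read, and the other 4-nitrophenyl, shared by compound 1 and compound 3, remains untested against any replacement such as 4-aminophenyl or 4-carboxyphenyl.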